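Amine substitution on the cyclohexylmethyl amide tail

The compounds below may be only part of what the source reports. "The series", "measured", "known", "first", "only" and "open" are said of these compounds alone.

Three compounds on the shared core have numbers in an assay on isolated protein for binding affinity to Gonadotropin-releasing hormone receptor (Rattus norvegicus); on this read-out higher numbers stand for weaker inhibition and lower numbers for stronger inhibition. Compound 1 `Cc1cc2c(cc1Cc1ccc(C(=O)NC[C@H]3CC[C@H](C(=O)O)CC3)o1)C(C)(C)CCC2(C)C` gives 3000 nM; compound 2 `Cc1ccc(CNC(=O)c2ccc(Cc3cc4c(cc3C)C(C)(C)CCC4(C)C)o2)cc1` gives 60 nM; compound 3 `Cc1cc2c(cc1Cc1ccc(C(=O)NCC3CCC(CN)CC3)o1)C(C)(C)CCC2(C)C` gives 730 nM. Compound 3 stands second highest of the three: the step of a 4.1-fold lower number from compound 1 to compound 3 (0.61 log units; beyond the scatter) puts it below compound 1, while the step of a 12-fold higher number from compound 2 to compound 3 (1.09 log units; beyond the scatter) leaves it well above compound 2. The further step a 50-fold lower number from compound 1 to compound 2 (1.70 log units; beyond the scatter) marks the widest gap seen so far.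

Compound 4 `Cc1cc2c(cc1Cc1ccc(C(=O)NCC3CCC(CNCc4c(C)noc4C)CC3)o1)C(C)(C)CCC2(C)C` differs from compound 3 by (3,5-dimethyl-1,2-oxazol-4-yl)methyl in place of hydrogen on an amine nitrogen. For the measured compounds named here, none of the measured steps touches this amine nitrogen; the two steps ending at compound 3 change the group on the saturated chain carbon bound to the amide nitrogen, not what hangs on the amine. They therefore bear only loosely on the new change. With nothing closer to go on, the expected step in this assay is a 1.8-fold lower number from compound 3 to compound 4 (0.26 log units; within the scatter), a modest one at most, and a result within the scatter of compound 3 would not be surprising. Compound 4 is thus estimated at 400 nM, with a range from 100 nM to 1600 nM.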

Compound 4, inhibition constant: 1200 nM
Compound 4: the middle estimate sits 3.0-fold (0.48 log units) below what was measured; measured number inside the range.
By their numbers in this assay, from the lowest: compound 2; then compounds 3 and 4 (each within the scatter of the next); then compound 1.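

On the amine nitrogen, in this assay, (3,5-dimethyl-1,2-oxazol-4-yl)methyl in place of hydrogen gives a 1.6-fold higher number from compound 3 to compound 4 (0.22 log units; within the scatter) and so stays within the usual scatter. For the compounds shown here, this position therefore accepts an entering group of 8 heavy atoms, including one five-membered aromatic ring, without a step beyond the scatter; the earlier steps all changed the group on the saturated chain carbon bound to the amide-type nitrogen and could not show this. No measurement available here explains the result.

A small group such as methyl on this amine nitrogen, or an acetyl group turning it into an amide, remains untested among the compounds shown. Also open, as far as these compounds go, is whether a benzyl group on the same nitrogen would behave like the (3,5-dimethyl-1,2-oxazol-4-yl)methyl group.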